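Aryl Groups Lift Inhibition of Ovarian Cancer Cells

The compounds below may be only part of what the source reports. "The series", "measured", "known", "first", "only" and "open" are said of these compounds alone.

Compound 3 `COc1ccc(-c2cn3ccnc3c(-c3ccc4ncn(C5CCCCC5)c4c3)n2)cc1` gives 71.2% in a functional assay on OVCAR-8 cells (Homo sapiens) for inhibition, read by sulforhodamine B assay, with a stated time of 48 h, tested at 10 uM; on this read-out lower numbers stand for less inhibition and higher numbers for more inhibition at the one concentration tested (going by the name of the read-out). It stands highest of the three measured compounds, yet compound 2 `c1ccc(-c2cn3ccnc3c(-c3ccc4ncn(C5CCCCC5)c4c3)n2)cc1` with 63.9% lies within the scatter of it; only compound 1 `Brc1cn2ccnc2c(-c2ccc3ncn(C4CCCCC4)c3c2)n1` with 4.92% lies far below, as the steps of a number 59 percentage points higher from compound 1 to compound 2 (beyond the scatter) and a number 66.3 percentage points higher from compound 1 to compound 3 (beyond the scatter) show. Compound 4 `O=Cc1ccc(-c2cn3ccnc3c(-c3ccc4ncn(C5CCCCC5)c4c3)n2)cc1` differs from compound 3 by formyl in place of methoxy on an aromatic carbon. The step that bears on this most is a number 7.3 percentage points higher from compound 2 to compound 3 (within the scatter), where adding the methoxy group hardly moved the number. Exchanging one group for another at the same place is therefore expected to stay within the scatter, giving a number 5.2 percentage points lower from compound 3 to compound 4 (within the scatter). Compound 4 is expected to give 66%, with a range from 45% to 85%.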

Compound 4, a percentage reported as inhibition, at one concentration (the size of the read-out at that concentration, not a potency): 44%
For compound 4 the middle estimate is 22 percentage points above the measured one, outside the stated range (below it).
By their numbers in this assay, from the lowest: compound 1; then compound 4; then compounds 2 and 3 (each within the scatter of the next).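

In this assay this position proves sensitive to the group it carries: formyl gives a number 27.2 percentage points lower from compound 3 to compound 4 (beyond the scatter) and a number 19.9 percentage points lower from compound 2 to compound 4 (beyond the scatter), a separation that methoxy and hydrogen did not show. The aryl gain over bromo is only partly kept, with a number 39.1 percentage points higher from compound 1 to compound 4 (beyond the scatter). Nothing available explains why formyl behaves differently from methoxy.

Going by these compounds, what an amine or a carboxylic acid at this same place would give stays open. So does whether any group here could rise clearly beyond compound 3.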